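The source may report more compounds than this note shows. Statements on the series, on what has been measured and on what is new or still open speak of the compounds shown alone.

Compound 2 `CN/C(=N/C#N)NCCCc1c[nH]c(C)n1` is the starting point. In a functional assay on Sf9 cells for antagonist activity at histamine H2 receptor (Homo sapiens), read by scintillation counting and GTPgammaS binding, with a stated time of 90 min (a lower number here means a less potent compound, a higher number a more potent compound, by a factor of ten per unit of this negative logarithm), compound 2 gives < 5, which is a limit of the assay rather than a number. Compound 1 `CN/C(=N/C#N)NCCCCc1c[nH]c(C)n1` is a close relative. In this assay compound 1 gives < 5, also a limit. Among the measured compounds shown here, both rest at the limit of < 5 in this assay, at which 2 of the 2 values shown sit, so no step between them can be sized. Compound 3 `Cc1nc(CCCN/C(=N\C#N)NCCSc2ccccc2)c[nH]1` differs from compound 2 by (phenylsulfanyl)methyl in place of hydrogen on a saturated chain carbon bound to an amine nitrogen. For the measured compounds named here, no measured step covers such a change, so the step of a number at least 0.30 log units higher from compound 2 to compound 3 (that floor lies within the scatter) is expected to be only a modest gain, and the assay may again report a limit. Compound 3 is estimated at 5.3, within 4.5 to 6.2.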

Compound 3, negative logarithm of the antagonist equilibrium constant: < 5
Compound 3 was reported as a limit (the forecaster's own chance of this, stated with the estimate: 40%); middle value at least 0.30 log units from the limit.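

No step can be read between compound 2 and compound 3, since each result is a limit of the assay, as with all values here: the limit of < 5 in this assay, at which 3 of the 3 values shown sit.

Whether the (phenylsulfanyl)methyl group changes potency at all remains open, since every compound shown rests at that limit.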